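Extending the chain on the oxygen-bound carbon

The source may hold more compounds than are shown below. What is called first, only, known or untested is meant among the compounds shown, and "the series" means these compounds.

Compound 2 `CO/N=C/c1cc(OC)c2c(c1OC)C(=O)C=CC2=O` carries a hydrogen on a saturated chain carbon bound to an oxygen on an unsaturated carbon. In a functional assay on A549 cells (Homo sapiens) for antiproliferative activity (on this read-out higher numbers stand for an effect only at larger amounts of compound and lower numbers for an effect already at smaller amounts), compound 2 gives > 10 ug/mL, which is a limit of the assay and not a number. Compound 1 `CCCCCCCO/N=C/c1cc(OC)c2c(c1OC)C(=O)C=CC2=O` carries a longer chain in that place; in this assay compound 1 gives > 10 ug/mL, likewise only a limit. Compound 3 `CCCCCC/C(=N\OCCC)c1cc(OC)c2c(c1OC)C(=O)C=CC2=O`, with a further chain on the unsaturated carbon, gives in this assay > 10 ug/mL, again a limit. Within the data shown here, compound 2 therefore stands where every value so far stands: at the limit of > 10 ug/mL in this assay, at which 3 of the 3 values shown sit. Among the measured compounds shown here, the one step measured around compound 2, a step that the two limits leave unreadable from compound 1 to compound 2, is a step between two limits and its size cannot be read.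

Compound 4 `CCCCCCCCCO/N=C/c1cc(OC)c2c(c1OC)C(=O)C=CC2=O` differs from compound 2 by octyl in place of hydrogen on a saturated chain carbon bound to an oxygen on an unsaturated carbon. For the measured compounds named here, the only step that bears on this change is a step that the two limits leave unreadable from compound 1 to compound 2, and it gives no readable size, so no step beyond the scatter can be expected in either direction in this assay. Compound 4 is accordingly expected to sit near the same limit, with an estimate of 15 ug/mL and a range from 7 ug/mL to 40 ug/mL; the implied step that the limit leaves unreadable from compound 2 to compound 4 is an expectation only, most likely to appear as a limit once more.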

Compound 4, concentration for half-maximal effect: > 10 ug/mL
Compound 4: a limit, no number (the forecaster's own chance of this, stated with the estimate: 75%); the middle value is on the limit's open side.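

In this assay compound 4, like compound 1 and compound 2, stands only at a limit of the assay, so no step among these compounds can be read. The compounds shown leave open whether any chain on the saturated chain carbon bound to an oxygen on an unsaturated carbon gives a readable value at all.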